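The compounds below may be only part of what the source reports. "The series", "measured", "known", "first", "only" and "open" are said of these compounds alone.

Measured so far:
compound 1 `COc1cc(-c2cc(C(=O)O)c3ccccc3n2)ccc1OCC(=O)Nc1cccc(C)c1`: 225000 nM
compound 2 `COc1cc(-c2cc(C(=O)O)c3ccccc3n2)ccc1OCC(=O)Nc1ccc(C)cc1`: > 300000 nM, a limit
compound 3 `COc1cc(-c2cc(C(=O)O)c3ccccc3n2)ccc1OCC(=O)Nc1ccccc1F`: 161000 nM

In an ADME assay on HaCaT cells (Homo sapiens) for inhibition (a higher number here means a weaker inhibitor, a lower number a stronger inhibitor), compound 3 gives 161000 nM, the lowest of the two numbers; compound 1 gives 225000 nM, and the step of a 1.4-fold lower number from compound 1 to compound 3 (0.15 log units; within the scatter) lies within the scatter. Compound 2 reaches only the limit > 300000 nM, which is the limit of > 300000 nM in this assay, at which 1 of the 3 values shown sits.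

Compound 4 `COc1cc(-c2cc(C(=O)O)c3ccccc3n2)ccc1OCC(=O)Nc1cccc(Cl)c1` differs from compound 3 in one place: 3-chlorophenyl in place of 2-fluorophenyl on an amide-type nitrogen. Within the data shown here, two measured steps concern the same aryl on the amide-type nitrogen: a 1.4-fold lower number from compound 1 to compound 3 (0.15 log units; within the scatter) and an at least 1.8-fold lower number from compound 2 to compound 3 (0.27 log units; that floor lies within the scatter), neither beyond the scatter. No step beyond the scatter is therefore expected for a 1.1-fold higher number from compound 3 to compound 4 (0.02 log units; within the scatter) in this assay. Compound 4 is estimated at 170000 nM, within 80000 nM to 350000 nM.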

Compound 4, half-maximal inhibitory concentration: 192000 nM
Compound 4: middle estimate off by 1.1-fold (0.05 log units), on the low side, and the stated range covers the measured number.
By their numbers in this assay, from the lowest: compounds 3, 4 and 1 (each within the scatter of the next). At a limit, above all of these: compound 2.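

In this assay, chloro in place of methyl on an aromatic carbon gives a 1.2-fold lower number from compound 1 to compound 4 (0.07 log units; within the scatter), and 3-chlorophenyl in place of 2-fluorophenyl gives a 1.2-fold higher number from compound 3 to compound 4 (0.08 log units; within the scatter), so three measured forms of this aryl on the amide-type nitrogen now sit within the scatter of one another. Against compound 2 only a floor can be read: an at least 1.5-fold lower number from compound 2 to compound 4 (0.19 log units; that floor lies within the scatter). Compound 2 stays at a limit: the limit of > 300000 nM in this assay, at which 1 of the 4 values shown sits.

Open, going by these compounds, is whether an amine or a carboxylic acid on this phenyl, or a longer chain in its place, gives a step beyond the scatter.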